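The compounds below may be only part of what the source reports. "The series", "measured", "known", "first", "only" and "open" are said of these compounds alone.

Compound 1 `O=C(NCN1CCC(c2cccc[n+]2[O-])CC1)c1cc(Cl)cc(Cl)c1` is the higher of the two compounds measured in a functional assay on HEK293 cells for agonist activity at D(4) dopamine receptor (Homo sapiens), read by FLIPR (a lower number here means a smaller maximal response, a higher number a larger maximal response), where compound 1 reaches 64%. Its nearest neighbour, compound 2 `[O-][n+]1ccccc1C1CCN(Cc2nc3ccccc3[nH]2)CC1`, gives 54% in this assay, a gap that lies within the scatter. Compound 3 `Cc1cc(C(=O)NCN2CCC(c3cccc[n+]3[O-])CC2)ccc1Cl` has not been measured; it differs from compound 1 by 4-chloro-3-methylphenyl in place of 3,5-dichlorophenyl on a carbonyl carbon. No measured step of this kind exists among these compounds, so the expected step is small, a number 4 percentage points lower from compound 1 to compound 3 (within the scatter), with no direction claimed beyond the scatter. For compound 3 the estimate in this assay is 60%, ranging from 40% to 80%.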

Compound 3, largest response reached (reported as efficacy), in percent of the reference or control that the assay uses: 62%
For compound 3 the middle estimate is 2 percentage points below the measured one; the range from low to high includes it.
By their numbers in this assay, from the lowest: compounds 2, 3 and 1 (each within the scatter of the next).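

Within the data shown here, on a carbonyl carbon whose other neighbour is an amide-type nitrogen, the first readable step at this position in this assay is 4-chloro-3-methylphenyl in place of 3,5-dichlorophenyl (a number 2 percentage points lower from compound 1 to compound 3 (within the scatter)). The entering group carries one chlorine and the leaving group two, yet the two compounds remain within the scatter of each other. No measurement bears on why this exchange leaves the maximal response unresolved. Going by these compounds, whether a phenyl carrying an amine or a carboxylic acid on this carbonyl carbon would fall in the same range remains open.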